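Swapping cyano for benzyloxycarbonyl on the chain

A few compounds are considered here, and "the series" means these few. Any claim that something is new, unique, unknown or untested is made for them only; others in the source may bear on it.

Compound 1 `COc1ccc(-c2cc3c(OC)cc(OC)cc3n(CCCC#N)c2=O)cc1`: 10000 nM
Compound 2 `COc1ccc(-c2cc3c(OC)cc(OC)cc3n(CCC#N)c2=O)cc1`: 10000 nM

In a functional assay on MCF7 cells (Homo sapiens) for cytotoxicity, read by colorimetric assay and MTT assay (on this read-out higher numbers stand for weaker inhibition and lower numbers for stronger inhibition), compound 2 gives 10000 nM, which puts it level with compound 1. The next molecule, compound 3 `COc1ccc(-c2cc3c(OC)cc(OC)cc3n(CCC(=O)OCc3ccccc3)c2=O)cc1`, differs from compound 2 as follows: benzyloxycarbonyl in place of cyano on a saturated chain carbon, two bonds along the chain from an aromatic nitrogen. In short, benzyloxycarbonyl stands in place of cyano on a saturated chain carbon, two bonds along the chain from an aromatic nitrogen.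

For the measured compounds named here, only one measured step bears on this position, the swap of cyanomethyl for cyano, and it showed no change at the digits printed from compound 1 to compound 2 (within the scatter). That swap brought in no ring, whereas the new group does, so it is only weak guidance. With no measured shift at this position, no clear direction is expected in this assay. The expected change is a 1.3-fold lower number from compound 2 to compound 3 (0.10 log units; within the scatter), with wide uncertainty. For compound 3 the estimate is 8000 nM, with an expected range of 2500 nM to 20000 nM.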

Compound 3, half-maximal inhibitory concentration: 10000 nM
Beside the measured number, compound 3's estimate is 1.3-fold (0.10 log units) below it, within the range that was stated.
By their numbers in this assay, from the lowest: compounds 1, 2 and 3 (each within the scatter of the next).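

In this assay, a much larger group on this chain leaves the number where it was: benzyloxycarbonyl in place of cyano gives no change at the digits printed from compound 2 to compound 3 (within the scatter) and benzyloxycarbonyl in place of cyanomethyl gives no change at the digits printed from compound 1 to compound 3 (within the scatter). For the compounds shown here, the earlier step brought in no ring, so this is the first sign that adding 10 heavy atoms, including a six-membered aromatic ring of carbon only, on a saturated chain carbon, two bonds along the chain from an aromatic nitrogen, does not shift the read-out. No supporting data are available to explain why the number stays level.

The compounds shown leave open whether a carboxylic acid or an amine on this chain would lower the number. They also leave open whether any change to the shared core would do so.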